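Hydroxy-to-amino swap on the shared core: second instance

The source may report more compounds than this note shows. Statements on the series, on what has been measured and on what is new or still open speak of the compounds shown alone.

Of the compounds shown here, three on a shared core have been measured in a functional assay on MCF7 cells (Homo sapiens) for inhibition, read by MTT assay, with a stated time of 2 days; a higher number here means a weaker inhibitor, a lower number a stronger inhibitor. Compound 1 `COc1ccccc1/C=C/c1cccc(O)c1` gives 24.3 ug/mL in this assay. Compound 2 `COc1ccccc1/C=C/c1ccc(O)cc1` gives 19 ug/mL in this assay. Compound 3 `COc1ccccc1/C=C/c1cccc(N)c1` gives 38.7 ug/mL in this assay. Compound 1 and compound 2 have the same atoms joined differently; the difference between the two cores is not broken down here. Compound 2 holds the lowest of the three numbers, yet its gap to compound 1 lies within the scatter, while its gap to compound 3 lies beyond it. Compound 3 differs from compound 1 by amino in place of hydroxy on an aromatic carbon, and this change gave a 1.6-fold higher number from compound 1 to compound 3 (0.20 log units; within the scatter), a step that stays within the scatter.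

Compound 4 `COc1ccccc1/C=C/c1ccc(N)cc1` is not yet measured in this assay. It differs from compound 2 by amino in place of hydroxy on an aromatic carbon. The two changes are of the same kind, not the same: in compound 3 the amino sits meta to a large group, in compound 4 it sits para to a large group. For the measured compounds named here, only one earlier instance of this change is available, so the expectation rests on it alone. The expected step from compound 2 to compound 4 in this assay is a 1.6-fold higher number from compound 2 to compound 4 (0.20 log units; within the scatter), which rests on the earlier step of a 1.6-fold higher number from compound 1 to compound 3 (0.20 log units; within the scatter). Compound 4 is therefore estimated at 30 ug/mL in this assay, with the range from 15 ug/mL to 60 ug/mL kept wide to allow for the changed place of the amino.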

Compound 4, half-maximal inhibitory concentration: 3.2 ug/mL
Compound 4: middle estimate off by 9.4-fold (0.97 log units), on the high side; the whole stated range lies above it.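

In this assay, amino in place of hydroxy on the core of compound 2 gives a clear drop in the number (a 5.9-fold lower number from compound 2 to compound 4 (0.77 log units; beyond the scatter)), so the step seen on the core of compound 1 does not carry over unchanged: the same change on two cores in this assay, a 1.6-fold higher number (0.20 log units; within the scatter) from compound 1 to compound 3 and a 5.9-fold lower number (0.77 log units; beyond the scatter) from compound 2 to compound 4, 9.5-fold (0.98 log units) apart, beyond the scatter of two such steps

This shows that, in this series, the outcome of the change cannot be read from one core and applied to the other, and that the two instances cannot be merged into one average step. It does not show what separates the two cores, since the amino of compound 4 sits para to a large group while the amino of compound 3 sits elsewhere, and two pairs cannot tell whether that difference in place accounts for the whole gap or give a rule for any further core.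

The compounds shown leave open whether the lower number of compound 4 needs a free amino group or would persist with a dimethylamino group, an acetamide or a methoxy group at the same place. They also leave open whether that result would hold with the methoxy group on the other ring replaced by a fluorine or a longer ether chain.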